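Alkyl extension on the core: compound 2 to compound 3

The compounds below may be only part of what the source reports. "The series", "measured", "known", "first", "only" and "open" are said of these compounds alone.

compound 1 `C[C@H](NC(=O)c1cnnn1Cc1ccc(C(F)(F)F)cc1)c1ccc(C(=O)O)cc1`: > 10000 nM
compound 2 `Cc1nnn(Cc2ccc(C(F)(F)F)cc2)c1C(=O)N[C@@H](C)c1ccc(C(=O)O)cc1`: > 10000 nM

In a functional assay on CHO cells for antagonist activity at prostaglandin E2 receptor EP4 subtype (Homo sapiens), read by calcium flux, with a stated time of 15 min (a higher number here means a weaker inhibitor, a lower number a stronger inhibitor), compound 1 returns only a limit, > 10000 nM. Compound 2 also stands at a limit, > 10000 nM. The step that the two limits leave unreadable from compound 1 to compound 2 therefore cannot be read. Compound 3 `CCc1nnn(Cc2ccc(C(F)(F)F)cc2)c1C(=O)N[C@@H](C)c1ccc(C(=O)O)cc1` differs from compound 2 by methyl in place of hydrogen on a saturated chain carbon bound to an aromatic carbon. Among the measured compounds shown here, no measured step bears on this change, and both measured values sit at the same limit (the limit of > 10000 nM in this assay, at which 2 of the 2 values shown sit). Compound 3 is expected to remain at the limit in this assay, with an estimate of 15000 nM and a range of 3000 nM to 60000 nM. The step that the limit leaves unreadable from compound 2 to compound 3 is thus expected to show no readable change; the expectation rests on compound 2 standing at > 10000 nM.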

Compound 3, half-maximal inhibitory concentration: > 10000 nM
Compound 3: no number, only a limit; the forecaster's own chance of this, stated with the estimate: 80%; the middle value is on the limit's open side.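

In this assay compound 3 gives only a limit, > 10000 nM, so no step among compound 1, compound 2 and compound 3 can be read: the limit of > 10000 nM in this assay, at which 3 of the 3 values shown sit.

Going by these compounds, whether these three compounds differ at all in this assay stays open.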